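Swapping the Ring on the Core Nitrogen

The source may hold more compounds than are shown below. What is called first, only, known or untested is meant among the compounds shown, and "the series" means these compounds.

Compound 1 `CN1CCN(c2ccc(Nc3ncc4nc(Nc5ccc(F)cc5)n([C@H]5CCCN(C(=O)CO)C5)c4n3)cc2)CC1`: in a functional assay on NCI-H1975 cells (Homo sapiens) for antiproliferative activity, read by MTT assay, with a stated time of 72 h (on this read-out lower numbers stand for stronger inhibition and higher numbers for weaker inhibition), compound 1 gives 750 nM.
Compound 2 `CN1CCN(c2ccc(Nc3ncc4nc(Nc5ccc(F)cc5)n([C@H]5CCN(C(=O)OC(C)(C)C)C5)c4n3)cc2)CC1`: in this assay compound 2 gives "not determined" (no result reported).

Within the data shown here, compound 1 is the only compound here with a number in this assay; compound 2 has none, so compound 1 stands alone and has nothing measured to be set against. Compound 3 `CN1CCN(c2ccc(Nc3ncc4nc(Nc5ccc(F)cc5)n([C@H]5CCN(S(=O)(=O)C6CC6)C5)c4n3)cc2)CC1` differs from compound 1 in a single place: 1-(cyclopropylsulfonyl)pyrrolidin-3-yl in place of 1-((hydroxymethyl)carbonyl)piperidin-3-yl on an aromatic nitrogen. Among the measured compounds shown here, no measured pair shows what such an exchange does in this assay, so neither the size nor the direction of the step can be read from anything measured so far. The expectation is a step of about a 1.3-fold lower number from compound 1 to compound 3 (0.10 log units; within the scatter) from compound 1, which means nothing beyond the usual scatter of repeated runs. Compound 3 is estimated at 600 nM in this assay, with a range from 150 nM to 2500 nM.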

Compound 3, half-maximal inhibitory concentration: 580 nM
The estimate for compound 3 lay 1.0-fold (0.01 log units) above the measured number, within the range that was stated.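

In this assay, among these compounds, this is the first measured step at this position on the aromatic nitrogen: a 1.3-fold lower number from compound 1 to compound 3 (0.11 log units; within the scatter). The two substituents differ in ring size and in the group on the ring nitrogen, yet the step stays within the scatter, so this exchange leaves the read-out effectively unmoved and the position tolerates both groups. Nothing available explains this result.

On these data alone, the ring and the group on its nitrogen changed together, so their separate contributions remain unknown; telling them apart would take a matched compound such as one carrying 1-(cyclopropylsulfonyl)piperidin-3-yl. Also open, as far as these compounds go, is how a free secondary amine on the pyrrolidine ring, or a carboxylic acid on a longer chain attached to that ring nitrogen, would read here.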